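Adding Ethoxycarbonyl to the Phenyl Compound

The compounds below may be only part of what the source reports. "The series", "measured", "known", "first", "only" and "open" are said of these compounds alone.

Compound 1 `COc1cc(-c2ccnc3cc(-c4ccccc4)nn23)cc(OC)c1OC`: 458 nM
Compound 2 `COc1cc(-c2ccnc3cc(-c4ccc5c(ccn5C)c4)nn23)cc(OC)c1OC`: 19 nM
Compound 3 `COc1cc(-c2ccnc3cc(-c4ccc5cc[nH]c5c4)nn23)cc(OC)c1OC`: 125 nM

In a functional assay on HeLa cells (Homo sapiens) for inhibition, read by CCK-8 assay, with a stated time of 48 h (a higher number here means a weaker inhibitor, a lower number a stronger inhibitor), compound 1 has the highest number of the three, 458 nM, and both other compounds lie beyond the scatter from it. Compound 4 `CCOC(=O)c1ccc(-c2cc3nccc(-c4cc(OC)c(OC)c(OC)c4)n3n2)cc1` keeps the core of compound 1 and differs in one place: ethoxycarbonyl in place of hydrogen on an aromatic carbon. Two measured steps start from the phenyl ring of compound 1. One is large, a 24-fold lower number from compound 1 to compound 2 (1.38 log units; beyond the scatter), and one is modest, a 3.7-fold lower number from compound 1 to compound 3 (0.56 log units; beyond the scatter). Both swap the whole ring for an indole rather than adding a group to it. The modest 6.6-fold higher number from compound 2 to compound 3 (0.82 log units; beyond the scatter) shows that the two indoles themselves differ. Going by the values given here, no measured compound carries a group on the phenyl ring, so these steps give only weak guidance and do not set a direction for this change. No step beyond the scatter is therefore expected in this assay, although a sizeable move either way remains possible. The expected step is a 1.1-fold higher number from compound 1 to compound 4 (0.04 log units; within the scatter). For compound 4 the estimated value is 500 nM, with an expected range from 120 nM to 2000 nM.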

Compound 4, half-maximal inhibitory concentration: > 10000 nM
Compound 4 was reported as a limit; the forecaster's own chance of this, stated with the estimate: 5%; at least 20-fold (1.30 log units) between middle value and limit.
By their numbers in this assay, from the lowest: compound 2; then compound 3; then compound 1. At a limit, above all of these: compound 4.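

In this assay, adding ethoxycarbonyl to an aromatic carbon para to a large group on the phenyl ring of compound 1 gives a large step: an at least 21-fold higher number from compound 1 to compound 4 (1.33 log units; beyond the scatter). Compound 4 is reported only as a limit, not as a number: the limit of > 10000 nM in this assay, at which 1 of the 4 values shown sits. It is the only compound shown that carries an added group on this ring, and it shows that a change here can raise the number, whereas replacing the whole ring with an indole in compound 2 and compound 3 lowered it.

This single example leaves open whether the loss belongs to ethoxycarbonyl itself or to any sizeable group at this place. As far as these compounds go, how a carboxylic acid, an amide or a methoxy group would behave at the same carbon remains open, as does the true size of the step.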